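The compounds below may be only part of what the source reports. "The series", "measured", "known", "first", "only" and "open" are said of these compounds alone.

Compound 1 `COc1cccc2c1c(C(=O)/C=C(\O)C(=O)O)cn2Cc1ccc(F)c(F)c1` is measured in an ADME assay on MT4 cells (Homo sapiens) for cytotoxicity, read by MTT assay (on this read-out higher numbers stand for lower toxicity in this test and lower numbers for higher toxicity in this test), at 71000 nM. Compound 2 `COc1cccc2c1c(C(=O)/C=C(\O)C(=O)O)cn2Cc1ccc(F)cc1` differs from compound 1 by hydrogen in place of fluoro on an aromatic carbon, and in this assay compound 2 gives 41100 nM; the step is a 1.7-fold lower number from compound 1 to compound 2 (0.24 log units; within the scatter). Compound 3 `CCOC(=O)/C(O)=C/C(=O)c1cn(Cc2c(F)ccc(F)c2F)c2cccc(OC)c12` is built on a core that differs from that of compound 1, but the difference between the two cores is not broken down here. In this assay compound 3 gives 40500 nM, a number that stands close to that of compound 2 and to that of compound 1. Compound 4 `CCOC(=O)/C(O)=C/C(=O)c1cn(Cc2cc(F)ccc2F)c2cccc(OC)c12` has not yet been measured. It differs from compound 3 by hydrogen in place of fluoro on an aromatic carbon. Among the compounds with values here, this is the same kind of change as the one from compound 1 to compound 2, but not the same: in compound 3 the carbon that loses its fluoro is ortho to a large group and meta to a fluoro group, whereas in compound 1 it is meta to a large group. Because a 1.7-fold lower number from compound 1 to compound 2 (0.24 log units; within the scatter) stayed within the scatter, a step of similar size is expected here, a 1.2-fold lower number from compound 3 to compound 4 (0.08 log units; within the scatter), and this rests on that single measured pair alone. Compound 4 is therefore expected to give about 34000 nM in this assay, with a likely range from 15000 nM to 80000 nM.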

Compound 4, half-maximal cytotoxic concentration: 41200 nM
Estimate against measurement, compound 4: 1.2-fold (0.08 log units) below, and the stated range covers the measured number.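

Replacing fluoro with hydrogen on the 2,3,6-trifluorobenzyl group, which leaves 2,5-difluorobenzyl, gives in this assay a 1.0-fold higher number from compound 3 to compound 4 (0.01 log units; within the scatter). Set beside the same kind of change on the core of compound 1, this step shows no difference between the two cores that can be told from scatter: the same change on two cores in this assay, a 1.7-fold lower number (0.24 log units; within the scatter) from compound 1 to compound 2 and a 1.0-fold higher number (0.01 log units; within the scatter) from compound 3 to compound 4, 1.8-fold (0.24 log units) apart, within the scatter of two such steps. This shows that, in these two pairs, the change leaves the read-out within the scatter on both cores, but it does not show that the change is without effect, nor does it give a rule for the series, since it rests on two pairs in which the carbon that loses its fluoro is not placed alike.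

The compounds shown carry only fluoro and hydrogen on the benzyl ring, with a carboxylic acid or an ethyl ester at the end of the chain. From the compounds shown here alone, what a chloro group, a methyl group or an amine on that ring, or an amide in place of the ester, would do in this assay stays open.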